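A few compounds are considered here, and "the series" means these few. Any claim that something is new, unique, unknown or untested is made for them only; others in the source may bear on it.

Measured so far in a functional assay on DU-145 cells (Homo sapiens) for inhibition, read by trypan blue exclusion, with a stated time of 96 h; on this read-out lower numbers stand for stronger inhibition of growth and higher numbers for weaker inhibition of growth:
- compound 1, `COc1ccc(OC)c(/C=C(/SCc2ccc(Cl)c(Cl)c2)C(=O)c2ccc(Cl)cc2)c1`: compound 1 gives 10000 nM
- compound 2, `Cc1ccc(CS/C(=C/c2c(O)cc(O)cc2O)C(=O)c2ccc(Cl)cc2)cc1`: compound 2 gives 50000 nM

Compound 1 holds the lower of the two numbers; compound 2 stands higher by a gap beyond the usual scatter, so compound 1 shows the stronger growth inhibition of the pair. Compound 3, `O=C(/C(=C\c1ccc(O)cc1)SCc1ccc(Cl)c(Cl)c1)c1ccc(Cl)cc1`, has not yet been measured. It differs from compound 1 in a single place: 4-hydroxyphenyl in place of 2,5-dimethoxyphenyl on a double-bonded chain carbon bound to a double-bonded chain carbon. Among the compounds with values here, no two measured compounds differ in one place alone, so no measured step bears directly on this change, and compound 2 differs from compound 1 in several places at once. Within the data shown here, the expected step is a 1.5-fold higher number from compound 1 to compound 3 (0.18 log units; within the scatter), modest and toward weaker inhibition, since the one measured compound bearing hydroxyl groups, compound 2, gave the higher number. Compound 3 is accordingly estimated at 15000 nM, with a range from 4000 nM to 60000 nM.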

Compound 3, concentration for 50% growth inhibition: 1000 nM
The estimate for compound 3 lay 15-fold (1.18 log units) above the measured number; measured number below the stated range.
By their numbers in this assay, from the lowest: compound 3; then compound 1; then compound 2.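

In this assay, 4-hydroxyphenyl in place of 2,5-dimethoxyphenyl on a double-bonded chain carbon bound to a double-bonded chain carbon gives a 10-fold lower number from compound 1 to compound 3 (1.00 log units; beyond the scatter). Within the data shown here, this is the first single-place change seen here, and it shows that the group at this position can by itself move the number beyond the scatter, with a hydroxyl-bearing ring on the side of stronger growth inhibition. The entering group has fewer heavy atoms and brings a hydrogen-bond donor, while the leaving group has more hydrogen-bond acceptors, and this one step cannot separate these differences.

On these data alone, it remains open whether a phenyl group carrying an amine or a carboxylic acid at this position would match compound 3. Nothing at hand accounts for the size or direction of this step.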